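Three sulfonamides at the limit and a fourth to estimate

A few compounds are considered here, and "the series" means these few. Any claim that something is new, unique, unknown or untested is made for them only; others in the source may bear on it.

Compound 3 `COc1ccc(S(=O)(=O)Nc2ccc3oc(-c4ccc(NC(=O)c5ccc(Cl)s5)cc4)nc3c2)cc1` shares its core with compound 1 `COc1ccc(S(=O)(=O)Nc2ccc(-c3nc4cc(NS(=O)(=O)c5ccc(OC)cc5)ccc4o3)cc2)cc1` and compound 2 `COc1ccc(S(=O)(=O)Nc2ccc3oc(-c4ccc(NC(=O)c5cccc(C)c5[N+](=O)[O-])cc4)nc3c2)cc1`. In an assay on isolated protein for inhibition of thiosulfate sulfurtransferase (Homo sapiens) (on this read-out higher numbers stand for weaker inhibition and lower numbers for stronger inhibition), compound 3 gives only a limit, > 100000 nM. In this assay compound 1 also gives a limit, > 100000 nM. In this assay compound 2 gives a limit as well, > 100000 nM. Compound 3 therefore stands together with both others at the limit, described by the limit of > 100000 nM in this assay, at which 3 of the 3 values shown sit, and none of the three can be ordered against the others.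

Compound 4 `COc1ccc(S(=O)(=O)Nc2ccc3oc(-c4ccc(NS(=O)(=O)c5cc(Br)ccc5OC)cc4)nc3c2)cc1` differs from compound 3 in one place: (5-bromo-2-methoxyphenyl)sulfonyl in place of (5-chlorothiophen-2-yl)carbonyl on a nitrogen on an aromatic ring. The measured steps that touch the same nitrogen are a step that the two limits leave unreadable from compound 1 to compound 2, a step that the two limits leave unreadable from compound 1 to compound 3 and a step that the two limits leave unreadable from compound 2 to compound 3, and all three are unreadable because each rests on (the limit of > 100000 nM in this assay, at which 3 of the 3 values shown sit). Going by the values given here, no measured step gives a size or a direction for an exchange at this position, so the expectation for compound 4 rests on the three limits alone.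

Compound 4 is expected to remain at the limit, with an estimated step of a number no higher from compound 3 to compound 4 (the limit leaves the size open). Compound 4 is estimated at 100000 nM, within a range from 30000 nM to 300000 nM.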

Compound 4, half-maximal inhibitory concentration: > 100000 nM
Compound 4: only a limit was reported; the forecaster's own chance of this, stated with the estimate: 85%; the middle value lies on the limit itself.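

The steps to compound 4 from compound 1, compound 2 and compound 3 cannot be read in this assay, because each rests on a limit: the limit of > 100000 nM in this assay, at which 4 of the 4 values shown sit.

The compounds shown leave open how strongly any of the four inhibits, and whether any exchange on this nitrogen changes inhibition at all.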